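Removing the propanoyl group from compound 3

The source may report more compounds than this note shows. Statements on the series, on what has been measured and on what is new or still open speak of the compounds shown alone.

In an ADME assay on MT4 cells (Homo sapiens) for cytotoxicity, read by MTT assay, with a stated time of 4 days (on this read-out higher numbers stand for lower toxicity in this test and lower numbers for higher toxicity in this test), compound 3 (`CCC(=O)Nc1c(C)c(C(OC(C)(C)C)C(=O)O)c(-c2ccc(C)c(C)c2)c(C)c1-c1ccc(C)c(C)c1`) gives 15000 nM and stands level with compound 1 (`Cc1ccc(-c2c(C)c(-c3ccc(C)c(C)c3)c(C(OC(C)(C)C)C(=O)O)c(C)c2NS(C)(=O)=O)cc1C`) at 15000 nM and within the scatter of compound 2 (`Cc1ccc(-c2c(C)c(-c3ccc(C)c(C)c3)c(C(OC(C)(C)C)C(=O)O)c(C)c2NC(=O)c2ccccc2)cc1C`), which gives 9100 nM here. Compound 4 (`Cc1ccc(-c2c(C)c(-c3ccc(C)c(C)c3)c(C(OC(C)(C)C)C(=O)O)c(C)c2N)cc1C`) has hydrogen in place of propanoyl on a nitrogen on an aromatic ring. Among the measured compounds shown here, the steps that bear on this exchange other groups on that nitrogen (a 1.6-fold lower number from compound 1 to compound 2 (0.22 log units; within the scatter); no change at the digits printed from compound 1 to compound 3 (within the scatter); a 1.6-fold higher number from compound 2 to compound 3 (0.22 log units; within the scatter)), and each lies within the scatter. For the measured compounds named here, no measured step leaves that nitrogen bare, so the evidence is indirect. The expected change in this assay is no step beyond the scatter (a 1.3-fold lower number from compound 3 to compound 4 (0.10 log units; within the scatter)). Compound 4 is estimated at 12000 nM, with an expected range from 6000 nM to 22000 nM in this read-out.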

Compound 4, half-maximal cytotoxic concentration: 12000 nM
Compound 4: middle estimate and measured number agree at the digits printed; the range from low to high includes it.
By their numbers in this assay, from the lowest: compounds 2, 4, 1 and 3 (each within the scatter of the next).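

In this assay, leaving the nitrogen bare gives a 1.3-fold lower number from compound 3 to compound 4 (0.10 log units; within the scatter) on losing propanoyl, a 1.3-fold higher number from compound 2 to compound 4 (0.12 log units; within the scatter) on losing benzoyl and a 1.3-fold lower number from compound 1 to compound 4 (0.10 log units; within the scatter) on losing methylsulfonyl. Across these four compounds, the presence or absence of a substituent on that nitrogen therefore produces no step beyond the scatter. No measurement at hand accounts for this flat result.

Going by these compounds, whether a longer acyl chain or a carboxylic acid carried on that nitrogen would also stay within the scatter remains open. The compounds shown say nothing about changes elsewhere on the shared core.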